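A few compounds are considered here, and "the series" means these few. Any claim that something is new, unique, unknown or untested is made for them only; others in the source may bear on it.

In a functional assay on A549 cells (Homo sapiens) for antiproliferative activity, read by MTT assay, with a stated time of 72 h (a lower number here means a stronger inhibitor, a higher number a weaker inhibitor), compound 1 (`Cc1nc(C)c(/C=C/C(=O)/C=C/c2ccc(O)cc2)nc1C`) gives 4010 nM and compound 2 (`Cc1nc(C)c(/C=C/C(=O)/C=C/c2ccccc2)nc1C`) gives 12300 nM while compound 3 (`Cc1nc(C)c(/C=C/C(=O)/C=C/c2ccc(F)cc2)nc1C`) gives 5900 nM on the same read-out. Compound 3 sits level with the hydroxy compound (a 1.5-fold higher number from compound 1 to compound 3 (0.17 log units; within the scatter)) and clear of the hydrogen compound (a 2.1-fold lower number from compound 2 to compound 3 (0.32 log units; beyond the scatter)). Compound 4 (`Cc1nc(C)c(/C=C/C(=O)/C=C/c2ccc(Cl)cc2)nc1C`) has chloro in place of fluoro on an aromatic carbon. Among the measured compounds shown here, no chloro compound has been measured yet, so the nearest guides are the two modest steps between hydrogen and a substituent (a 3.1-fold higher number from compound 1 to compound 2 (0.49 log units; beyond the scatter) and a 2.1-fold lower number from compound 2 to compound 3 (0.32 log units; beyond the scatter)) and the hydroxy-to-fluoro step within the scatter (a 1.5-fold higher number from compound 1 to compound 3 (0.17 log units; within the scatter)). Chloro is therefore expected to stay with fluoro, and no step beyond the scatter is expected in this assay here. The estimated step is small (a 1.2-fold lower number from compound 3 to compound 4 (0.07 log units; within the scatter)). Compound 4 is estimated at 5000 nM with 2500 nM to 10000 nM as the expected range.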

Compound 4, half-maximal inhibitory concentration: 15800 nM
Compound 4: middle estimate off by 3.2-fold (0.50 log units), on the low side; the whole stated range lies below it.
By their numbers in this assay, from the lowest: compounds 1 and 3 (each within the scatter of the next); then compounds 2 and 4 (each within the scatter of the next).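

In this assay the two halogens at this position do not read as one group: (a 2.7-fold higher number from compound 3 to compound 4 (0.43 log units; beyond the scatter)), so the gain fluoro shows over hydrogen does not carry over to chloro. Chloro stays level with the unsubstituted compound (a 1.3-fold higher number from compound 2 to compound 4 (0.11 log units; within the scatter)) and falls short of the hydroxy compound (a 3.9-fold higher number from compound 1 to compound 4 (0.60 log units; beyond the scatter)), leaving compound 1 and compound 3 as the stronger pair among the four. Nothing available here accounts for the split between fluoro and chloro.

On these data alone, whether bromo, methoxy or an amine on the same carbon would group with compound 1 and compound 3 or with compound 2 and compound 4 remains open.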